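The source may hold more compounds than are shown below. What is called first, only, known or untested is meant among the compounds shown, and "the series" means these compounds.

Three analogues built on one shared core have been tested in a functional assay on WiDr cells (Homo sapiens) for inhibition, read by sulforhodamine B assay, with a stated time of 48 h; on this read-out lower numbers stand for stronger inhibition of growth and higher numbers for weaker inhibition of growth. Compound 1 `COC(=O)[C@@]1(C)CCC=C2[C@@H]1CC[C@@H](C)[C@]2(C)Cc1c[nH]c2ccccc12` gives 8700 nM. Compound 2 `COC(=O)[C@@]1(C)CCC=C2[C@@H]1CC[C@@H](C)[C@]2(C)Cc1c[nH]c2ccc(Cl)cc12` gives 20000 nM, and compound 3 `COC(=O)[C@@]1(C)CCC=C2[C@@H]1CC[C@@H](C)[C@]2(C)Cc1c(C)[nH]c2ccccc12` gives 19000 nM; compound 3 thus holds the second highest of the three numbers, close to compound 2 and clearly above compound 1. The move to compound 4 `COC(=O)[C@@]1(C)CCC=C2[C@@H]1CC[C@@H](C)[C@]2(C)Cc1c(C)[nH]c2ccc(Cl)cc12` is chloro in place of hydrogen on an aromatic carbon. This same change has been seen once already: a 2.3-fold higher number from compound 1 to compound 2 (0.36 log units; beyond the scatter), a modest weakening. The methyl carried by compound 3 produced a step of similar size, a 2.2-fold higher number from compound 1 to compound 3 (0.34 log units; beyond the scatter). If the chloro step repeats on compound 3, a modest rise in number is expected in this assay. Compound 4 is therefore estimated at 44000 nM, within 15000 nM to 120000 nM. That estimate amounts to an expected 2.3-fold higher number from compound 3 to compound 4 (0.36 log units; beyond the scatter).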

Compound 4, concentration for 50% growth inhibition: 18000 nM
The estimate for compound 4 lay 2.4-fold (0.39 log units) above the measured number; measured number inside the range.
By their numbers in this assay, from the lowest: compound 1; then compounds 4, 3 and 2 (each within the scatter of the next).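

With the methyl already present, the chloro gives a 1.1-fold lower number from compound 3 to compound 4 (0.02 log units; within the scatter), and with the chloro already present, the methyl gives a 1.1-fold lower number from compound 2 to compound 4 (0.05 log units; within the scatter), so in this assay neither group shifts the number beyond the scatter once the other is there, although each did so alone on compound 1. This is only a hint that the two changes do not add up, as the chloro change on the two cores does not differ firmly: the same change on two cores in this assay, a 2.3-fold higher number (0.36 log units; beyond the scatter) from compound 1 to compound 2 and a 1.1-fold lower number (0.02 log units; within the scatter) from compound 3 to compound 4, 2.4-fold (0.38 log units) apart, within the scatter of two such steps. The methyl change reads the same way: the same change on two cores in this assay, a 2.2-fold higher number (0.34 log units; beyond the scatter) from compound 1 to compound 3 and a 1.1-fold lower number (0.05 log units; within the scatter) from compound 2 to compound 4, 2.4-fold (0.38 log units) apart, within the scatter of two such steps.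

Going by these compounds, whether a fluoro or a methoxy in place of the chloro, or an ethyl in place of the methyl, would behave alike stays open.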